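The source may hold more compounds than are shown below. What is called first, only, known or untested is meant among the compounds shown, and "the series" means these compounds.

For the measured compounds named here, in an ADME assay on the whole organism (strain Sprague-Dawley) for pharmacokinetics, with Rattus norvegicus as the target, at a dose of 10 mg/kg by the oral route (on this read-out higher numbers stand for higher exposure at the dose given and lower numbers for lower exposure), compound 2 (`O=C(NOCCO)c1cc2ccoc2c(F)c1Nc1ccc(I)cc1F`) gives 8370 ng.h/mL, the highest of the two numbers so far, clearly above compound 1 (`O=C(NOC[C@H](O)CO)c1cc2ccoc2c(F)c1Nc1ccc(I)cc1F`) at 2860 ng.h/mL. Compound 3 (`O=C(NOC(CO)CO)c1cc2ccoc2c(F)c1Nc1ccc(I)cc1F`) differs from compound 2 by a single change: hydroxymethyl in place of hydrogen on a saturated chain carbon bound to an oxygen and a saturated chain carbon. Going by the values given here, compound 1 also carries a hydroxymethyl that compound 2 lacks, though at another place on the chain, so the one measured step that bears on this change is a 2.9-fold higher number from compound 1 to compound 2 (0.47 log units; beyond the scatter). Run in reverse, it suggests a drop of similar size, an expected 2.8-fold lower number from compound 2 to compound 3 (0.45 log units; beyond the scatter). Compound 3 is estimated at 3000 ng.h/mL, with an expected range of 1200 ng.h/mL to 7500 ng.h/mL.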

Compound 3, area under the concentration-time curve: 43300 ng.h/mL
Compound 3: middle estimate off by 14-fold (1.16 log units), on the low side, outside the stated range (above it).
By their numbers in this assay, from the lowest: compound 1; then compound 2; then compound 3.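

Hydroxymethyl on this saturated chain carbon raises the number instead of lowering it, giving a 5.2-fold higher number from compound 2 to compound 3 (0.71 log units; beyond the scatter). The place of the added hydroxymethyl on the chain therefore matters: 2-hydroxy-1-(hydroxymethyl)ethyl in place of 2,3-dihydroxypropyl on the oxygen gives a 15-fold higher number from compound 1 to compound 3 (1.18 log units; beyond the scatter). Nothing measured here says why the two placements differ so much. Still open, on these data alone, is whether the second hydroxyl itself is needed, or whether a methoxymethyl or an aminomethyl on this carbon would give a similar number. As far as these compounds go, whether the same change would raise the number on a different core also remains unknown.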